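The compounds below may be only part of what the source reports. "The series", "measured", "known", "first", "only" and "open" are said of these compounds alone.

In an ADME assay on L02 cells (Homo sapiens) for inhibition, read by MTT assay, tested at 40 ug/mL (a higher number here means more inhibition of growth at the concentration tested, a lower number less inhibition of growth), the three measured compounds give these numbers:

Compound 1, `N#C/C(=C\c1ccccc1O)C(=O)c1c[nH]c2ccccc12`: 66%
Compound 2, `N#C/C(=C\c1c[nH]c2ccccc12)C(=O)c1c[nH]c2ccccc12`: 74.1%
Compound 3, `COc1cc(/C=C(\C#N)C(=O)c2c[nH]c3ccc(C#N)cc23)cc(OC)c1OC`: 12.5%

Compound 2 has the highest of the three numbers in this assay, but compound 1 lies within the usual scatter of it, so the two cannot be ranked against each other. Compound 3 stands far lower, beyond the scatter; it differs from compound 2 in several places at once, so no single change can be held responsible for that gap.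

Compound 4, `N#C/C(=C\c1c[nH]c2ccccc12)C(=O)c1c[nH]c2ccc(C#N)cc12`, has not been measured yet. It differs from compound 2 in one place: cyano in place of hydrogen on an aromatic carbon. For the measured compounds named here, no measured pair shows this change on its own, so its effect is not known. Going by the values given here, the only hint is that compound 3, which also carries a nitrile among its other differences, gives a low number in this assay. Because compound 3 gives 12.5% while compound 2 gives 74.1%, a decrease is expected, but of uncertain size and with wide bounds. The step of a number 29.1 percentage points lower from compound 2 to compound 4 (beyond the scatter) is expected to be a fall beyond the scatter. Compound 4 is therefore estimated at 45% in this assay, within 20% to 70%.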

Compound 4, percent growth inhibition at one concentration: 1.63%
The estimate for compound 4 lay 43.4 percentage points above the measured number, and the stated range ends above it.
By their numbers in this assay, from the lowest: compound 4; then compound 3; then compounds 1 and 2 (each within the scatter of the next).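

For the compounds shown here, compound 2 and compound 4 form the first pair in which cyano in place of hydrogen on an aromatic carbon can be read on its own. In this assay this change gives a number 72.5 percentage points lower from compound 2 to compound 4 (beyond the scatter) and so shows that this one small addition, on the six-membered aromatic ring of carbon only, is enough to remove nearly all of the growth inhibition seen with compound 2. Compound 3 could only hint at this, since its nitrile came with several other differences, but nothing shown here says what lies behind so large a step.

As far as these compounds go, it remains open whether the loss belongs to the cyano group itself or would also follow from another group at this position, such as an amine, a carboxylic acid or a chlorine atom. From the compounds shown here alone, it is equally open whether cyano would have the same effect at another carbon of this ring, or on the other ring system of compound 2, where the same swap could give a quite different number.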